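A few compounds are considered here, and "the series" means these few. Any claim that something is new, unique, unknown or untested is made for them only; others in the source may bear on it.

Of the compounds shown here, two with the same core have been measured so far in a physicochemical assay for lipophilicity, at pH 7.4; on this read-out lower numbers stand for lower lipophilicity and higher numbers for higher lipophilicity: compound 1 `CCNC(=O)C1CCN(c2cncnc2-c2ccccc2)CC1` and compound 2 `CN(C)C(=O)C1CCN(c2cncnc2-c2ccccc2)CC1`. Within the data shown here, compound 1 gives 1.8 and compound 2 gives 1.7, so compound 2 stands within the usual scatter of the only other measured number.

The next compound is compound 3 `CCN(C)C(=O)C1CCN(c2cncnc2-c2ccccc2)CC1`. Its difference from compound 2 is methyl in place of hydrogen on a saturated chain carbon bound to an amide-type nitrogen, which turns dimethylamino into ethyl(methyl)amino.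

Among the measured compounds shown here, only one measured step bears on this change: a number 0.10 log units lower from compound 1 to compound 2 (within the scatter), with dimethylamino in place of ethylamino on a carbonyl carbon. That step exchanges one group for another, while the new change puts methyl in place of hydrogen, so it offers only indirect guidance. For the measured compounds named here, no measured pair shows this exact change. The small step seen from compound 1 to compound 2 gives no sign of a large swing in this assay, and the structural change alone points to a modest move upward.

The expected result is a number 0.40 log units higher from compound 2 to compound 3 (beyond the scatter). For compound 3, the estimated value is 2.1, with an expected range from 1.8 to 2.4.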

Compound 3, distribution coefficient: 2.1
Compound 3: middle estimate and measured number agree at the digits printed; low and high end bracket the measured number.
By their numbers in this assay, from the lowest: compounds 2, 1 and 3 (each within the scatter of the next, the first and the last beyond it).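

In this assay, among these compounds, methyl in place of hydrogen on a saturated chain carbon bound to an amide-type nitrogen gives a number 0.40 log units higher from compound 2 to compound 3 (beyond the scatter), the first step in this small set to go beyond the scatter, so a change of a single methyl at this place can show up clearly on the read-out. Compound 3 can also be reached from compound 1 by methyl in place of hydrogen on an amide-type nitrogen, and that route gives a number 0.30 log units higher from compound 1 to compound 3 (within the scatter), so the numbers do not separate these two compounds even though one carries the amide hydrogen and the other does not. No measurement is available that explains either step.

The compounds shown leave open whether the number would keep moving in the same direction with a longer chain such as propyl or butyl in place of the ethyl, since a single methyl step cannot show a trend. They also leave open what a hydroxyl group, an amine or a carboxylic acid in place of that ethyl would do to the read-out in this assay.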